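A Fluorine Swap on the Pyridine Amine of Compound 2

The source may hold more compounds than are shown below. What is called first, only, known or untested is meant among the compounds shown, and "the series" means these compounds.

Compound 1 `Cc1ccc(Nc2ncc([C@H](NC(=O)c3nccs3)C(C)(C)C)cc2Cl)cn1` and compound 2 `CCC[C@@H](NC(=O)c1nccs1)c1cnc(Nc2cccnc2)c(Cl)c1` share a chloropyridine core carrying a thiazole amide. In a functional assay on HEK293 cells for negative allosteric modulation of metabotropic glutamate receptor 5 (Homo sapiens), read by HTRF and inositol phosphate accumulation (a lower number here means a stronger inhibitor, a higher number a weaker inhibitor), compound 1 gives 30.9 nM. In this assay compound 2 gives 71.4 nM, which is the higher of the two numbers, and the gap to compound 1 lies beyond the usual scatter, so compound 2 is the weaker inhibitor of the pair.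

Compound 3 `CCC[C@@H](NC(=O)c1nccs1)c1cnc(Nc2ccc(F)nc2)c(Cl)c1` differs from compound 2 in a single place: fluoro in place of hydrogen on an aromatic carbon. Among the measured compounds shown here, no measured pair in this set isolates this exact change, so there is no direct precedent to lean on. With only a single fluorine entering and nothing else moving, the step from compound 2 to compound 3 is expected to be small, close to or within the scatter, with a slight lean toward a lower number; the expected step is a 1.3-fold lower number from compound 2 to compound 3 (0.11 log units; within the scatter). For compound 3 in this assay the estimate is 55 nM, with a likely range from 20 nM to 150 nM.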

Compound 3, half-maximal inhibitory concentration: 12.8 nM
Compound 3: the middle estimate sits 4.3-fold (0.63 log units) above what was measured, and the stated range ends above it.
By their numbers in this assay, from the lowest: compound 3; then compound 1; then compound 2.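

Going from pyridin-3-yl to 6-fluoropyridin-3-yl gives a 5.6-fold lower number from compound 2 to compound 3 (0.75 log units; beyond the scatter) in this assay and that step lies beyond the usual scatter, so this aromatic carbon, next to the ring nitrogen and para to a large group, is a place where one added fluorine atom clearly lowers the number. The earlier compounds shown here could not show this, since compound 1 and compound 2 differ in more than one place and so neither of them isolates a change at this carbon. Nothing available here accounts for the size of the step, so it stands as an observation without a known cause.

Going by these compounds, whether the lower number is particular to fluoro stays open, and a methoxy group or a nitrile on the same carbon would test whether other groups give a step of similar size. On these data alone, it is also open whether the fluorine would give a comparable step in a compound with a different chain in place of the propyl chain, such as a cyclopropylmethyl group.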